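A few compounds are considered here, and "the series" means these few. Any claim that something is new, unique, unknown or untested is made for them only; others in the source may bear on it.

Compound 1 `Cc1noc(C)c1-c1cnc(N)c(Oc2ccc(C(=O)NC3CCCC3)cc2)n1`: 9970 nM
Compound 2 `Cc1noc(C)c1-c1cnc(N)c(Oc2ccc(C(=O)Nc3ccc(Cl)cc3)cc2)n1`: 2230 nM

Both were measured in a functional assay on HeLa cells (Homo sapiens) for inhibition, read by MTT assay, with a stated time of 72 h; a higher number here means a weaker inhibitor, a lower number a stronger inhibitor. Within the data shown here, compound 2 has the lower of the two numbers, and the only measured step is a 4.5-fold lower number from compound 1 to compound 2 (0.65 log units; beyond the scatter), a change on the amide nitrogen.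

Compound 3 `Cn1cc(-c2cnc(N)c(Oc3ccc(C(=O)Nc4ccc(Cl)cc4)cc3)n2)cn1` differs from compound 2 in one place: 1-methyl-1H-pyrazol-4-yl in place of 3,5-dimethyl-1,2-oxazol-4-yl on an aromatic carbon. The measured step of a 4.5-fold lower number from compound 1 to compound 2 (0.65 log units; beyond the scatter) concerns a different part of the molecule, so nothing measured here bears on the change to compound 3. With no guide, the expected step from compound 2 to compound 3 is a 1.1-fold higher number from compound 2 to compound 3 (0.05 log units; within the scatter). Compound 3 is therefore estimated at 2500 nM, within a wide range from 700 nM to 9000 nM.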

Compound 3, half-maximal inhibitory concentration: 3440 nM
Estimate against measurement, compound 3: 1.4-fold (0.14 log units) below; the measured number falls inside the stated range.
By their numbers in this assay, from the lowest: compounds 2 and 3 (each within the scatter of the next); then compound 1.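

Replacing 3,5-dimethyl-1,2-oxazol-4-yl with 1-methyl-1H-pyrazol-4-yl gives a 1.5-fold higher number from compound 2 to compound 3 (0.19 log units; within the scatter) in this assay. The earlier step concerned the amide nitrogen, whereas this one shows that, at this aromatic carbon, these two five-membered aromatic rings cannot be told apart by this read-out. No measurement available here explains this result. Going by these compounds, how a simple amine or a carboxylic acid would behave on this carbon remains open. So does whether 1-methyl-1H-pyrazol-4-yl would give the same outcome alongside the cyclopentyl amide of compound 1.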